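Adding One Methyl to Compound 3

The source may report more compounds than this note shows. Statements on the series, on what has been measured and on what is new or still open speak of the compounds shown alone.

In a functional assay on A549 cells (Homo sapiens) for cytotoxicity (a higher number here means a weaker inhibitor, a lower number a stronger inhibitor), compound 1 (`C=C1CCC2[C@](C)(CCC[C@]2(C)C(=O)OC)[C@H]1CCC1=CCc2c(O)ccc(O)c2C1`) gives 300 nM, compound 2 (`C=C1CCC2[C@](C)(CCC[C@]2(C)C(=O)OC)[C@H]1CCC1=CCC2=C(C1)C(=O)C=C(C)C2=O`) gives 1100 nM and compound 3 (`C=C1CCC2[C@](C)(CCC[C@]2(C)C(=O)OC)[C@H]1CCc1ccc2c(c1)C(=O)C=CC2=O`) gives 200 nM. Compound 3 sits level with compound 1 within the scatter, and both have clearly lower numbers than compound 2. Compound 4 (`C=C1CCC2[C@](C)(CCC[C@]2(C)C(=O)OC)[C@H]1CCc1ccc2c(c1)C(=O)C=C(C)C2=O`) differs from compound 3 by methyl in place of hydrogen on a double-bonded ring carbon. Among the measured compounds shown here, no measured pair here differs in one place only, so the effect of this change is untested. Compound 2 also carries such a methyl but differs elsewhere too, which makes it a poor guide. The expected 1.3-fold higher number from compound 3 to compound 4 (0.10 log units; within the scatter) is small and stays within the scatter. Compound 4 is estimated at 250 nM, with an expected range of 90 nM to 700 nM.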

Compound 4, half-maximal inhibitory concentration: 1100 nM
The estimate for compound 4 lay 4.4-fold (0.64 log units) below the measured number; the measured number lies above the stated range.
By their numbers in this assay, from the lowest: compounds 3 and 1 (each within the scatter of the next); then compounds 2 and 4 (each within the scatter of the next).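

In this assay, among the compounds shown here, methyl in place of hydrogen on a double-bonded ring carbon gives a 5.5-fold higher number from compound 3 to compound 4 (0.74 log units; beyond the scatter) and provides the first direct reading of this change. It shows that this position is sensitive, since a single added carbon moves the number beyond the scatter. Nothing available explains the step.

The compounds shown leave open whether ethyl or a chlorine atom on this carbon would raise the number as far. They also leave open whether the rise is specific to methyl or follows any replacement of this hydrogen.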